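Chain extension on the bis-azetidine core

The source may report more compounds than this note shows. Statements on the series, on what has been measured and on what is new or still open speak of the compounds shown alone.

Measured so far:
compound 1, `CCCCCCCCCCCCCCc1nc(OC2CCC2)nc(N2CCC2)c1O`: 109%
compound 2, `CCCCCCCCCCCCCCCCc1nc(OC2CCC2)nc(N2CCC2)c1O`: 102%
compound 3, `CCCCCCCCCCCCCCc1nc(N2CCC2)nc(N2CCC2)c1O`: 86%

All three were tested in a functional assay on cells (Lymphocyte, Homo sapiens), read by a luciferase reporter and ATP content, with a stated time of 48 h, tested at 1 uM; a higher number here means a weaker effect of the compound at the concentration tested, a lower number a stronger effect. Compound 2 arises from compound 1 by ethyl in place of hydrogen on a saturated chain carbon, ten or more bonds along the chain from an aromatic carbon; the step of a number 7 percentage points lower from compound 1 to compound 2 (within the scatter) falls inside the scatter, so the longer chain is not seen to change the read-out on this core. Compound 3 arises from compound 1 by azetidin-1-yl in place of cyclobutyloxy on an aromatic carbon; the step of a number 23 percentage points lower from compound 1 to compound 3 (beyond the scatter) is beyond the scatter, and compound 3 stands with the lowest number of the three.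

Compound 4, `CCCCCCCCCCCCCCCCc1nc(N2CCC2)nc(N2CCC2)c1O`, has not been measured. It arises from compound 3 by ethyl in place of hydrogen on a saturated chain carbon, ten or more bonds along the chain from an aromatic carbon; this is the same change as that from compound 1 to compound 2, made at the same place on a different core, the two cores differing as described for compound 1 and compound 3. Among the measured compounds shown here, with only one prior instance of this change, and that one within the scatter, the step of a number 6 percentage points lower from compound 3 to compound 4 (within the scatter) is expected to be small for compound 4 in this assay, resting on the step of a number 7 percentage points lower from compound 1 to compound 2 (within the scatter). Compound 4 is therefore estimated at 80%, between 62% and 98%.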

Compound 4, a percentage reported as activity, at one concentration (the size of the read-out at that concentration, not a potency): 92%
Beside the measured number, compound 4's estimate is 12 percentage points below it; the range from low to high includes it.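

In this assay the ethyl in place of hydrogen on the saturated chain carbon gives a number 6 percentage points higher from compound 3 to compound 4 (within the scatter), and the two instances of this change do not differ: the same change on two cores in this assay, a number 7 percentage points lower (within the scatter) from compound 1 to compound 2 and a number 6 percentage points higher (within the scatter) from compound 3 to compound 4, 13 percentage points apart, within the scatter of two such steps. On the longer chain, azetidin-1-yl in place of cyclobutyloxy gives a number 10 percentage points lower from compound 2 to compound 4 (within the scatter), and the gap to the earlier instance also stays inside what two such steps can show: the same change on two cores in this assay, a number 23 percentage points lower (beyond the scatter) from compound 1 to compound 3 and a number 10 percentage points lower (within the scatter) from compound 2 to compound 4, 13 percentage points apart, within the scatter of two such steps. Both changes therefore carry from one core to the other without a detectable difference, but each comparison rests on a single pair of steps, and this does not show that the steps are equal, nor that the azetidin-1-yl step keeps its size, as it lies beyond the scatter in one instance and within it in the other.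

The compounds shown leave open whether a shorter chain, or a chain ending in a carboxylic acid, would move the read-out on either core. Also open, going by these compounds, is what an amine such as morpholine would give in place of azetidin-1-yl.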